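The compounds below may be only part of what the source reports. "The series", "measured", "known", "first", "only" and "open" are said of these compounds alone.

Measured compounds:
compound 1 `Cc1ccc(-c2c(S(=O)(=O)c3ccccc3)cnc3cc(C)nn23)cc1`, in a functional assay on the whole organism for inhibition, with Mus musculus as the target, with a stated time of 3 h, at a dose of 50 mg/kg by the oral route (on this read-out lower numbers stand for less inhibition and higher numbers for more inhibition at the one dose given (going by the name of the read-out)), compound 1 gives 23.2%
compound 2 `Cc1ccc(-c2c(S(=O)(=O)c3ccccc3)cnc3ncnn23)cc1`, compound 2 gives 4.4%
compound 3 `Cc1cc2ncc(S(=O)(=O)c3ccccc3)c(-c3ccc(Br)cc3)n2n1`, compound 3 gives 4.4%

Compound 1 stands highest of the three numbers in this assay; the step of a number 18.8 percentage points lower from compound 1 to compound 3 (beyond the scatter) puts compound 3 well below it, and compound 2 shows a number as low as that of compound 3, so both gaps from compound 1 lie beyond the usual scatter.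

Compound 4 `Cc1ccc(-c2c(S(=O)(=O)c3ccccc3)cnc3cc(-c4ccccc4)nn23)cc1` is yet to be measured. It differs from compound 1 in one place: phenyl in place of methyl on an aromatic carbon. Within the data shown here, no measured step touches this position; the only step on record, a number 18.8 percentage points lower from compound 1 to compound 3 (beyond the scatter), changes the substituent on the pendant aryl ring, not a group on the shared core, and its size is modest. Among the measured compounds shown here, the change from compound 1 to compound 2, for which no single step is counted here, also alters the core and goes along with a lower number. On this thin basis, compound 4 is expected to fall somewhat below compound 1, an expected step of a number 8.2 percentage points lower from compound 1 to compound 4 (within the scatter). The estimate for compound 4 is 15%, expected to lie between 0% and 38%.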

Compound 4, a percentage reported as inhibition, in the whole organism at one dose (the size of the read-out at that dose, not a potency): 36.4%
Beside the measured number, compound 4's estimate is 21.4 percentage points below it; the range from low to high includes it.
By their numbers in this assay, from the lowest: compounds 2 and 3 (each within the scatter of the next); then compound 1; then compound 4.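

In this assay, among these compounds, phenyl in place of methyl on this aromatic carbon of the five-membered ring gives a number 13.2 percentage points higher from compound 1 to compound 4 (beyond the scatter) and is the first change in one place to raise the number. Among the compounds shown here, the only earlier step, a number 18.8 percentage points lower from compound 1 to compound 3 (beyond the scatter) with bromo in place of methyl, went the other way at a different place, so the two steps show that the outcome depends on the change and where it is made, and that this carbon of the shared core can carry a six-membered aromatic ring with a gain at this dose. Nothing available explains the rise.

From the compounds shown here alone, whether an amine, a carboxylic acid or a longer chain such as butyl on this carbon would raise or lower the number remains open. So does whether a phenyl bearing its own substituents would keep the gain.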